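This account rests on a few compounds, and the source may have more. Where it says the series, first, only, none or still open, it means among the compounds named here.

Three compounds that share one core and differ only in the group carried on a saturated ring carbon have been tested in a functional assay on BGC-823 cells (Homo sapiens) for antiproliferative activity, read by MTT assay, tested at 1 uM; on this read-out higher numbers stand for a stronger effect at the one concentration tested and lower numbers for a weaker effect. There compound 1 `COc1cc(C2=NN(C(C)=O)C(c3c(Cl)cccc3Cl)O2)cc(OC)c1OC` gives -1.4%, compound 2 `COc1cc(C2=NN(C(C)=O)C(c3ccccc3C(F)(F)F)O2)cc(OC)c1OC` gives 31.8%, and compound 3 `COc1cc(C2=NN(C(C)=O)C(c3ccc(F)c(F)c3)O2)cc(OC)c1OC` gives 18.3%. Compound 3 thus stands second highest of the three: a number 13.5 percentage points lower from compound 2 to compound 3 (beyond the scatter), while a number 19.7 percentage points higher from compound 1 to compound 3 (beyond the scatter). Compound 4 `COc1cc(C2=NN(C(C)=O)C(c3cccc(C(F)(F)F)c3)O2)cc(OC)c1OC` differs from compound 3 in one place: 3-(trifluoromethyl)phenyl in place of 3,4-difluorophenyl on a saturated ring carbon. Going by the values given here, no measured step swaps these two groups directly. The nearest guide is compound 2, whose ring also bears a trifluoromethyl and gave the highest number, with a number 33.2 percentage points higher from compound 1 to compound 2 (beyond the scatter). A modest rise is therefore expected, a number 8.7 percentage points higher from compound 3 to compound 4 (within the scatter). Compound 4 is estimated at 27%, within 10% to 45%.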

Compound 4, a percentage reported as inhibition, at one concentration (the size of the read-out at that concentration, not a potency): 27.9%
The estimate for compound 4 lay 0.9 percentage points below the measured number; measured number inside the range.
By their numbers in this assay, from the lowest: compound 1; then compounds 3, 4 and 2 (each within the scatter of the next, the first and the last beyond it).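

In this assay the change from 2-(trifluoromethyl)phenyl to 3-(trifluoromethyl)phenyl gives a number 3.9 percentage points lower from compound 2 to compound 4 (within the scatter) and so does not separate these two groups on the saturated ring carbon. The 3,4-difluorophenyl group, which stood apart from 2-(trifluoromethyl)phenyl, is also not separated from 3-(trifluoromethyl)phenyl, with a number 9.6 percentage points higher from compound 3 to compound 4 (within the scatter) as the step. Only 2,6-dichlorophenyl stays clearly apart, with a number 29.3 percentage points higher from compound 1 to compound 4 (beyond the scatter) as the step, and nothing available here explains these results. Still open, as far as these compounds go, is how an amine or a carboxylic acid on the phenyl ring would read out, or a longer chain in place of that ring.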